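Second hydroxy on the hydrazone aryl of compound 3

The source may report more compounds than this note shows. Statements on the series, on what has been measured and on what is new or still open speak of the compounds shown alone.

Measured so far:
compound 1 `CN(C)CCn1cnnc1-c1cc(Oc2ccc(NC(=O)N/N=C/c3ccc(O)c(O)c3)cc2F)ccn1`: > 100000 nM
compound 2 `CN(C)CCn1cnnc1-c1cc(Oc2ccc(NC(=O)N/N=C/c3cccc(Br)c3)cc2F)ccn1`: 830 nM
compound 3 `CN(C)CCn1cnnc1-c1cc(Oc2ccc(NC(=O)N/N=C/c3ccc(O)cc3)cc2F)ccn1`: 7750 nM

In a functional assay on U-87MG ATCC cells (Homo sapiens) for cytotoxicity, read by MTT assay, with a stated time of 72 h (on this read-out lower numbers stand for stronger inhibition and higher numbers for weaker inhibition), compound 3 gives 7750 nM, the highest of the two numbers, with compound 2 nearest at a 9.3-fold higher number from compound 2 to compound 3 (0.97 log units; beyond the scatter). The value of compound 1 is a limit of this assay (the limit of > 100000 nM in this assay, at which 1 of the 3 values shown sits). Compound 4 `CN(C)CCn1cnnc1-c1cc(Oc2ccc(NC(=O)N/N=C/c3ccc(O)cc3O)cc2F)ccn1` differs from compound 3 by hydroxy in place of hydrogen on an aromatic carbon. The most relevant measured step is the reverse move an at least 12-fold lower number from compound 1 to compound 3 (1.11 log units; beyond the scatter), where removing a hydroxy from the same aryl gave a large drop; adding one there again is expected to raise the number in this assay, with compound 1 suggesting it could reach the limit. For compound 4 a modest rise a 1.9-fold higher number from compound 3 to compound 4 (0.29 log units; within the scatter) is estimated, giving 15000 nM (range 4000 nM to 60000 nM).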

Compound 4, half-maximal inhibitory concentration: 15400 nM
For compound 4 the middle estimate is 1.0-fold (0.01 log units) below the measured one; the range from low to high includes it.
By their numbers in this assay, from the lowest: compound 2; then compounds 3 and 4 (each within the scatter of the next). At a limit, above all of these: compound 1.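

In this assay, a second hydroxy ortho to a large group and meta to the first hydroxy leaves the number within the scatter: a 2.0-fold higher number from compound 3 to compound 4 (0.30 log units; within the scatter). Where the second hydroxy sits therefore counts, since the 2,4-dihydroxyphenyl group stands apart from the 3,4-dihydroxyphenyl group, whose number is a limit: an at least 6.4-fold lower number from compound 1 to compound 4 (0.81 log units; beyond the scatter). Neither hydroxy pattern comes close to the 3-bromophenyl group: a 19-fold higher number from compound 2 to compound 4 (1.27 log units; beyond the scatter).

Open, as far as these compounds go, is whether a methoxy or an amine on the same aromatic carbon reads like the hydroxy. Also open, from the compounds shown here alone, is whether bromine there would match the 3-bromophenyl group.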